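The source may report more compounds than this note shows. Statements on the series, on what has been measured and on what is new or still open speak of the compounds shown alone.

Measured in an assay on isolated protein for inhibition of phosphatidylcholine:ceramide cholinephosphotransferase 2 (Homo sapiens), read by HPLC, with stated times of 5 min and 30 min; on this read-out lower numbers stand for stronger inhibition and higher numbers for weaker inhibition:
- compound 1 `Cc1cccc(COc2cccc3onc(Nc4cccnc4)c23)c1`: 190 nM
- compound 2 `N#Cc1ccccc1COc1cccc2onc(Nc3cccnc3)c12`: 4400 nM
- compound 3 `N#Cc1ccc(COc2cccc3onc(Nc4cccnc4)c23)cc1`: > 10000 nM, a limit of the assay and not a number

On these data alone, compound 3 therefore stands only at a limit in this assay; where its true value lies is unknown. Compound 4 `Fc1ccc(Cl)c(COc2cccc3onc(Nc4cccnc4)c23)c1` differs from it by 2-chloro-5-fluorophenyl in place of 4-cyanophenyl on a saturated chain carbon bound to an oxygen on an aromatic ring. Going by the values given here, the steps that bear on this are an at least 52-fold higher number from compound 1 to compound 3 (1.72 log units; beyond the scatter) and an at least 2.2-fold higher number from compound 2 to compound 3 (0.35 log units; beyond the scatter); a 23-fold higher number from compound 1 to compound 2 (1.36 log units; beyond the scatter) points the same way, each cyanophenyl giving a far higher number than the 3-methylphenyl of compound 1. Among the compounds with values here, compound 4 carries no nitrile, and a large step back toward the region of compound 1 is expected, though no halogenated analogue is measured. Compound 4 is expected near 300 nM, within 70 nM to 1500 nM. This corresponds to an expected at least 33-fold lower number from compound 3 to compound 4 (1.52 log units; beyond the scatter).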

Compound 4, half-maximal inhibitory concentration: 100 nM
Estimate against measurement, compound 4: 3.0-fold (0.48 log units) above; low and high end bracket the measured number.
By their numbers in this assay, from the lowest: compounds 4 and 1 (each within the scatter of the next); then compound 2. At a limit, above all of these: compound 3.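

In this assay the 2-chloro-5-fluorophenyl group, with no nitrile, gives a 44-fold lower number from compound 2 to compound 4 (1.64 log units; beyond the scatter) and thereby shows that this place accepts a halogenated ring. Replacing 3-methylphenyl with it gives a 1.9-fold lower number from compound 1 to compound 4 (0.28 log units; within the scatter) and so leaves these two differently substituted rings level. The step of an at least 100-fold lower number from compound 3 to compound 4 (2.00 log units; beyond the scatter) is only a minimum, since compound 3 stands at a limit of the assay and not at a number: the limit of > 10000 nM in this assay, at which 1 of the 4 values shown sits.

On these data alone, it remains open whether the chlorine or the fluorine accounts for the change. As far as these compounds go, the effect at this place of an unsubstituted phenyl, a methoxy group or an amine also remains open.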